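The source may report more compounds than this note shows. Statements on the series, on what has been measured and on what is new or still open speak of the compounds shown alone.

Measured so far:
compound 1 `CC(/N=c1\c(O)c(O)\c1=N/c1cnc2ccccc2c1)C(C)(C)C`
compound 2 `CC(C)(C)/N=c1\c(O)c(O)\c1=N/c1cnc2ccccc2c1`
compound 3 `CC(/N=c1\c(O)c(O)\c1=N/c1ccc(C#N)cc1)C(C)(C)C`

In a functional assay for inhibition, with Rattus norvegicus as the target (on this read-out lower numbers stand for stronger inhibition and higher numbers for weaker inhibition), compound 1 gives only a limit, > 30000 nM. Compound 2 also gives only a limit in this assay, > 30000 nM. The change between them, (tert-butyl in place of 1,2,2-trimethylpropyl on a double-bonded nitrogen), made a step that the two limits leave unreadable from compound 1 to compound 2; the step cannot be read because of the limit of > 30000 nM in this assay, at which 2 of the 3 values shown sit. For the measured compounds named here, compound 3 gives 520 nM in this assay, the only number in the set. The difference between the core of compound 3 and the core of compound 1 is not broken down here.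

Compound 4 `CC(C)(C)/N=c1\c(O)c(O)\c1=N/c1ccc(C#N)cc1` is not yet measured and carries the same change, (tert-butyl in place of 1,2,2-trimethylpropyl on a double-bonded nitrogen). Going by the values given here, the one measured instance of this change rests on two limits and shows neither its size nor its direction. The step this estimate means, a 1.5-fold higher number from compound 3 to compound 4 (0.19 log units; within the scatter), is expected to be small. Resting on compound 3 at 520 nM, compound 4 is expected at 800 nM, between 200 nM and 4000 nM.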

Compound 4, half-maximal inhibitory concentration: 560 nM
Compound 4: middle estimate off by 1.4-fold (0.15 log units), on the high side, within the range that was stated.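

In this assay, tert-butyl in place of 1,2,2-trimethylpropyl on a double-bonded nitrogen gives a 1.1-fold higher number from compound 3 to compound 4 (0.03 log units; within the scatter), so on the core of compound 3 the change has no readable effect. On the core of compound 1 the same change cannot be read, because compound 1 and compound 2 both give a limit and not a number: the limit of > 30000 nM in this assay, at which 2 of the 4 values shown sit.

The series therefore holds a single readable instance of this change, which does not show that the change carries from one core to another with the same size.

The compounds shown leave open how a methyl group, or a chain ending in an amine, on that nitrogen would read beside compound 3 and compound 4. They also leave open how a carboxylic acid in place of the nitrile would read on the core of compound 3.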